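This account rests on a few compounds, and the source may have more. Where it says the series, first, only, none or still open, it means among the compounds named here.

In a functional assay on HeLa cells (Homo sapiens) for inhibition, read by MTT assay, with a stated time of 48 h (on this read-out lower numbers stand for stronger inhibition and higher numbers for weaker inhibition), the three measured compounds stand as follows:

compound 1 `COc1ccc(-c2nc3cc(/C=C4\SC(=O)NC4=O)ccc3[nH]2)cc1OC` — 7830 nM
compound 2 `COc1cc(OC)c(-c2nc3cc(/C=C4\SC(=O)NC4=O)ccc3[nH]2)cc1OC` — 15400 nM
compound 3 `COc1cc(-c2nc3cc(/C=C4\SC(=O)NC4=O)ccc3[nH]2)ccc1OCC(C)C` — 5220 nM

Compound 1 gives the second highest of the three numbers in this assay. Its nearest neighbour is compound 3, and its furthest is compound 2, yet both steps stay inside the usual spread of repeated runs: a 1.5-fold lower number from compound 1 to compound 3 (0.18 log units; within the scatter) and a 2.0-fold higher number from compound 1 to compound 2 (0.29 log units; within the scatter). Nothing among these three therefore separates one compound from another with any confidence.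

Compound 4 `COc1ccc(-c2nc3cc(/C=C4\SC(=O)N(CC(=O)N5CCOCC5)C4=O)ccc3[nH]2)cc1OC` keeps the whole of compound 1 and alters a single place: ((morpholin-4-yl)carbonyl)methyl in place of hydrogen on an amide-type nitrogen in a ring. Among the measured compounds shown here, the two measured steps both concern the aromatic ring that carries the methoxy groups, and neither touches the ring nitrogen of the five-membered ring; so no measured step bears directly on this change. What the measured steps do show is that the shared core tolerated two changes of different kinds without moving beyond the scatter. On that basis a step of modest size, in either direction, is the most reasonable expectation, and the wide range reflects how little the data say about this nitrogen. The step is estimated as a 1.1-fold lower number from compound 1 to compound 4 (0.05 log units; within the scatter). Compound 4 is therefore expected to give about 7000 nM in this assay, within a range of 2000 nM to 25000 nM.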

Compound 4, half-maximal inhibitory concentration: 7510 nM
For compound 4 the middle estimate is 1.1-fold (0.03 log units) below the measured one; the range from low to high includes it.
By their numbers in this assay, from the lowest: compounds 3, 4, 1 and 2 (each within the scatter of the next, the first and the last beyond it).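

In this assay, among the compounds shown here, the step at the amide-type nitrogen in a ring is a 1.0-fold lower number from compound 1 to compound 4 (0.02 log units; within the scatter), and it is the first reading at this place, since the earlier steps concerned only the substituents on the methoxy-bearing aromatic ring. It shows that the amide hydrogen can give way to ((morpholin-4-yl)carbonyl)methyl, a group of 9 heavy atoms with one six-membered non-aromatic ring, while the number stays within the scatter of that of compound 1. The data shown offer nothing that would explain this outcome.

This single pair leaves open whether the same holds for other groups on this nitrogen, such as a plain methyl, a longer alkyl chain, an acetic acid side chain ending in a carboxylic acid, or an amide built from piperidine or piperazine in place of morpholine. It also leaves open whether ((morpholin-4-yl)carbonyl)methyl would behave the same way on the shared core when the aromatic ring carries the substituents of compound 2 or compound 3.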